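A few compounds are considered here, and "the series" means these few. Any claim that something is new, unique, unknown or untested is made for them only; others in the source may bear on it.

Measured compounds:
- compound 1 `O=C1N(c2cccc(Cl)c2)CCN1C1CN2CCC1CC2` gives 30.9 nM in a functional assay (Cavia porcellus) for antagonist activity at Serotonin 3 (5-HT3) receptor (Homo sapiens); a higher number here means a weaker inhibitor, a lower number a stronger inhibitor
- compound 2 `Cc1cccc(N2CCN(C3CN4CCC3CC4)C2=O)c1` gives 12 nM in this assay

Compound 2 has the lowest number of the two values in this assay; its nearest neighbour is compound 1, and the step of a 2.6-fold lower number from compound 1 to compound 2 (0.41 log units; beyond the scatter) lies beyond the scatter of this assay. The change from compound 2 to compound 3 `CSc1cccc(N2CCN(C3CN4CCC3CC4)C2=O)c1` is methylsulfanyl in place of methyl on an aromatic carbon. Among the compounds with values here, the only measured step, a 2.6-fold lower number from compound 1 to compound 2 (0.41 log units; beyond the scatter), swaps chloro for methyl at this same aromatic carbon and does not involve methylsulfanyl, so it bears on the new step only indirectly: it shows that the group at this position can move the number modestly. Within the data shown here, with no direct precedent, compound 3 is expected to stay close to compound 2, with a step of a 1.3-fold higher number from compound 2 to compound 3 (0.10 log units; within the scatter) not clearly beyond the scatter. Compound 3 is estimated at 15 nM in this assay, with a likely range from 5 nM to 45 nM.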

Compound 3, antagonist equilibrium constant: 214 nM
Compound 3: middle estimate off by 14-fold (1.15 log units), on the low side; measured number outside the range, above it.
By their numbers in this assay, from the lowest: compound 2; then compound 1; then compound 3.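

Replacing methyl with methylsulfanyl at this aromatic carbon gives an 18-fold higher number from compound 2 to compound 3 (1.25 log units; beyond the scatter) in this assay, a large step, whereas the swap of chloro for methyl, a 2.6-fold lower number from compound 1 to compound 2 (0.41 log units; beyond the scatter), was only modest. Methylsulfanyl also compares poorly with chloro, with a 6.9-fold higher number from compound 1 to compound 3 (0.84 log units; beyond the scatter), so of the three groups at this carbon, methyl gives the lowest number and methylsulfanyl the highest, with every step beyond the scatter. The data shown offer no measurement that explains this large rise.

Going by these compounds, it remains open whether the sulfur atom itself matters, which methoxy, the same group with oxygen in place of sulfur, could help to test. On these data alone, it is also open whether an amine or a carboxylic acid at this carbon would stay close to compound 2 or rise towards compound 3.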